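The source may hold more compounds than are shown below. What is called first, only, known or untested is meant among the compounds shown, and "the series" means these compounds.

Compound 1 `Oc1cccc(-c2cc(-c3ccco3)nc(-c3ccccc3Cl)c2)c1` is measured in a functional assay on HCT-15 cells (Homo sapiens) for cytotoxicity, read by CCK-8 assay and cell counting, with a stated time of 2 days (a higher number here means a weaker inhibitor, a lower number a stronger inhibitor), where compound 1 gives 2230 nM. Among the compounds with values here, compound 2 `Oc1ccc(-c2cc(-c3ccco3)nc(-c3ccccc3Cl)c2)cc1` carries 4-hydroxyphenyl in place of 3-hydroxyphenyl, and in this assay compound 2 gives 5460 nM; this is the only step on record, a 2.4-fold higher number from compound 1 to compound 2 (0.39 log units; beyond the scatter). Compound 3 `Oc1cccc(-c2cc(-c3ccccn3)nc(-c3ccccc3Cl)c2)c1` was entered into this assay, but for compound 3 the outcome is "not determined" (no result reported). Of the two numbers available, compound 1 stands with the lowest; compound 2 is the nearest, and compound 3 contributes no number.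

Compound 4 `Oc1cccc(-c2cc(-c3cccc(Cl)c3)nc(-c3ccco3)c2)c1` differs from compound 1 only in the chlorophenyl group: 3-chlorophenyl in place of 2-chlorophenyl on an aromatic carbon. Within the data shown here, no measured step alters the chlorophenyl group, so nothing on record bears directly on this change. Among the measured compounds shown here, the one recorded step, a 2.4-fold higher number from compound 1 to compound 2 (0.39 log units; beyond the scatter), exchanged 4-hydroxyphenyl for 3-hydroxyphenyl and was modest. For compound 4 a step of comparable size is expected, a 1.4-fold higher number from compound 1 to compound 4 (0.16 log units; within the scatter), with no firm direction. Compound 4 is therefore estimated to give about 3200 nM in this assay, in the range 1200 nM to 8500 nM.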

Compound 4, half-maximal inhibitory concentration: 2460 nM
Compound 4: the middle estimate sits 1.3-fold (0.11 log units) above what was measured; the measured number falls inside the stated range.
By their numbers in this assay, from the lowest: compounds 1 and 4 (each within the scatter of the next); then compound 2.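

Exchanging 2-chlorophenyl for 3-chlorophenyl at the position next to the ring nitrogen gives a 1.1-fold higher number from compound 1 to compound 4 (0.04 log units; within the scatter) in this assay, so the two chlorophenyl groups cannot be told apart in this assay. Within the data shown here, the only earlier step changed the hydroxyphenyl group and lay beyond the scatter, a 2.4-fold higher number from compound 1 to compound 2 (0.39 log units; beyond the scatter), whereas this is the first reading on the chlorophenyl group, and it shows no separation. Nothing available accounts for this result.

Open, from the compounds shown here alone, is how the number responds to 4-chlorophenyl at this position, or to an amine or a carboxylic acid on the same phenyl ring. Also open, going by these compounds, is whether the hydroxyphenyl step holds with 3-chlorophenyl in place, and what the group of compound 3 does in place of furan-2-yl, as compound 3 gives no number.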